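Aryl Exchange on the Carbonyl Carbon: Toward Compound 3

This account rests on a few compounds, and the source may have more. Where it says the series, first, only, none or still open, it means among the compounds named here.

Compound 2 `Cn1cccc1C(=O)/C=C/c1ccc2c(c1)B(O)OC2` carries a 1-methyl-1H-pyrrol-2-yl group on its carbonyl carbon. In a functional assay on HCT-116 cells (Homo sapiens) for cytotoxicity, read by MTT assay, with a stated time of 48 h (on this read-out lower numbers stand for stronger inhibition and higher numbers for weaker inhibition), compound 2 reaches only a limit of the assay, > 100000 nM, and not a number. Its single measured relative, compound 1 `O=C(/C=C/c1ccc2c(c1)B(O)OC2)c1cccnc1`, bears pyridin-3-yl at that same carbonyl carbon, and in this assay compound 1 gives 20500 nM. Among the measured compounds shown here, the one step seen so far, an at least 4.8-fold higher number from compound 1 to compound 2 (0.68 log units; beyond the scatter), ends at the limit of > 100000 nM in this assay, at which 1 of the 2 values shown sits. Compound 3 `O=C(/C=C/c1ccc2c(c1)B(O)OC2)c1ccc(I)cc1` differs from compound 2 by 4-iodophenyl in place of 1-methyl-1H-pyrrol-2-yl on a carbonyl carbon. For the measured compounds named here, only that single measured step bears on this change: going from a six-membered aromatic ring to the five-membered pyrrole weakened inhibition beyond the scatter, so a return to a six-membered carbon-only ring is expected to recover much of it, an expected step of an at least 3.3-fold lower number from compound 2 to compound 3 (0.52 log units; beyond the scatter). Compound 3 is accordingly estimated at 30000 nM, with a range from 10000 nM to 100000 nM.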

Compound 3, half-maximal inhibitory concentration: 11600 nM
Estimate against measurement, compound 3: 2.6-fold (0.41 log units) above; measured number inside the range.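

The exchange on the carbonyl carbon gives an at least 8.6-fold lower number from compound 2 to compound 3 (0.93 log units; beyond the scatter), the first sign that the weak result of the 1-methyl-1H-pyrrol-2-yl group can be undone by another aryl group at this place alone. For compound 2 the value is a limit and not a number, so this step is bounded on one side only: the limit of > 100000 nM in this assay, at which 1 of the 3 values shown sits. Set against pyridin-3-yl, the 4-iodophenyl group gives a 1.8-fold lower number from compound 1 to compound 3 (0.25 log units; within the scatter), so these two six-membered aromatic rings cannot be told apart here.

Going by these compounds, what a plain phenyl, a 4-chlorophenyl or a 4-aminophenyl group on the carbonyl carbon would give in this assay stays open, and with it whether the iodine plays any part. Also open, on these data alone, is whether the five-membered ring or its 1-methyl group goes with the weak result, which a thiophen-2-yl or an unmethylated pyrrol-2-yl group would address.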